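The compounds below may be only part of what the source reports. "The series", "measured", "known", "first", "only" and "open" are said of these compounds alone.

Measured so far in an ADME assay on microsomes from liver (Homo sapiens) for metabolic stability, tested at 2.5 uM; on this read-out lower numbers stand for slow clearance and higher numbers for fast clearance:
- compound 1 `COc1ccc(S(=O)(=O)c2cnc3cc(F)ccc3c2-c2cccc(F)c2)cc1` gives 2.94 mL/min
- compound 2 `Cc1ccc(S(=O)(=O)c2cnc3cc(F)ccc3c2-c2cccc(F)c2)cc1F` gives 0.41 mL/min

Among the compounds with values here, compound 2 stands lowest of the two numbers in this assay; its only neighbour is compound 1, and the single step between them, a 7.2-fold lower number from compound 1 to compound 2 (0.86 log units; beyond the scatter), exchanges the aryl on the sulfonyl sulfur. Compound 3 `O=S(=O)(c1ccc(F)c(Cl)c1)c1cnc2cc(F)ccc2c1-c1cccc(F)c1` is not yet measured. It differs from compound 2 in one place: 3-chloro-4-fluorophenyl in place of 3-fluoro-4-methylphenyl on a sulfonyl sulfur. Within the data shown here, only the step from compound 1 to compound 2 bears on this change, since it concerns the same position, the aryl on the sulfonyl sulfur, though with a different pair of groups. That step shows that exchanging this aryl can move the read-out beyond the scatter; it does not show in which direction the present exchange would move it. Among the measured compounds shown here, with no closer precedent, the expectation for compound 3 is a number near that of compound 2, with the step of a 1.3-fold higher number from compound 2 to compound 3 (0.13 log units; within the scatter) expected to remain within the scatter, and a broad range to either side. Compound 3 is therefore estimated at 0.55 mL/min, between 0.2 mL/min and 1.5 mL/min.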

Compound 3, intrinsic clearance in a liver preparation (reported as CLH), per the amount of preparation that the assay uses: 0.25 mL/min
Beside the measured number, compound 3's estimate is 2.2-fold (0.34 log units) above it, within the range that was stated.
By their numbers in this assay, from the lowest: compounds 3 and 2 (each within the scatter of the next); then compound 1.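

In this assay, 3-chloro-4-fluorophenyl in place of 3-fluoro-4-methylphenyl on a sulfonyl sulfur gives a 1.6-fold lower number from compound 2 to compound 3 (0.21 log units; within the scatter) on the read-out, so a chlorine-bearing aryl without a methyl cannot be told apart from the methyl-bearing aryl of compound 2. Replacing 4-methoxyphenyl at this place gives a 12-fold lower number from compound 1 to compound 3 (1.07 log units; beyond the scatter) and, with the step to compound 2, shows that two different halogen-bearing aryls each stand clearly apart from compound 1; among these three compounds no aryl goes against this, although three compounds carry a pattern only a short way. Nothing available explains why the aryl of compound 1 stands apart from the other two.

Open, going by these compounds, is whether the methoxy group itself goes with the higher number, or whether an ethoxy or a hydroxy group in its place, or fluorine added to the 4-methoxyphenyl, would read differently. Also open, on these data alone, is how far this read-out holds for aryls carrying an amine or a carboxylic acid, and for a pyridine or a cyclohexyl ring on the sulfonyl sulfur.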